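Replacing a sulfonyl group with a bicyclic amine substituent

A few compounds are considered here, and "the series" means these few. Any claim that something is new, unique, unknown or untested is made for them only; others in the source may bear on it.

Measured so far:
Compound 1, `CC(=O)c1cc(C(=O)N[C@H](C)Cn2ccc(-c3cc(F)c(C#N)c(Cl)c3)n2)n[nH]1`, in a functional assay on LNCaP cells (Homo sapiens) for antiproliferative activity, read by CCK-8 assay, with a stated time of 6 days (a lower number here means a stronger inhibitor, a higher number a weaker inhibitor), gives 1080 nM.
Compound 2, `C[C@@H](Cn1ccc(-c2ccc(C#N)c(Cl)c2)n1)NS(=O)(=O)c1cccnc1`, in this assay gives 6140 nM.

Of the two measured compounds, compound 2 has the higher number in this assay, and its nearest neighbour is compound 1, whose number is lower by a margin beyond the scatter. The two compounds differ in more than one place, so nothing is recorded about which of their differences accounts for that gap.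

Compound 3, `C[C@@H](Cn1ccc(-c2ccc(C#N)c(Cl)c2)n1)Nc1ncnc2nc[nH]c12`, is not yet measured. It differs from compound 2 in one place: a group of 9 heavy atoms (5 carbon, 4 nitrogen; one five-membered aromatic ring with 2 hetero atoms, one six-membered aromatic ring with 2 hetero atoms) in place of a group of 9 heavy atoms (5 carbon, 1 nitrogen, 2 oxygen, 1 sulfur; one six-membered aromatic ring with 1 hetero atom), on an amine nitrogen. Within the data shown here, no measured pair shows this change, so its effect can only be guessed. Because compound 2 sits at 6140 nM, there is room for movement in either direction, and a change of this size is likely to move the number beyond the scatter, though the direction is uncertain. The expected step of a 2.0-fold lower number from compound 2 to compound 3 (0.31 log units; beyond the scatter) is set as a modest improvement with a wide range. Compound 3 is expected to give about 3000 nM, between 600 nM and 15000 nM.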

Compound 3, half-maximal inhibitory concentration: 960 nM
Compound 3: the middle estimate sits 3.1-fold (0.49 log units) above what was measured; the measured number falls inside the stated range.
By their numbers in this assay, from the lowest: compounds 3 and 1 (each within the scatter of the next); then compound 2.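

In this assay, among these compounds, the swap on the amine nitrogen gives a 6.4-fold lower number from compound 2 to compound 3 (0.81 log units; beyond the scatter), the first change in one place alone, and it shows that the number responds to what sits on this nitrogen with the rest of compound 2 held fixed. The leaving (pyridin-3-yl)sulfonyl group and the entering group, with its five-membered and six-membered aromatic rings, have the same heavy-atom count, so the step comes with no change in that count, only with a different make-up: the sulfur and both oxygens go, more nitrogen comes in, and a hydrogen-bond donor appears. Nothing measured here explains why the step has this size or direction.

The compounds shown leave open which part of the swap carries the step: the loss of the sulfonyl link, the gain of the second ring, or the added donor, since all three change together in this single pair. A pyridin-3-yl group joined directly to the amine nitrogen, or an acetyl group in that place, would be needed to pull these apart.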